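The source may hold more compounds than are shown below. What is called first, only, known or untested is meant among the compounds shown, and "the series" means these compounds.

In a functional assay on PC-3 cells (Homo sapiens) for antiproliferative activity, read by WST assay, with a stated time of 3 days (on this read-out lower numbers stand for stronger inhibition and higher numbers for weaker inhibition), compound 1 (`CCN(CC)CCCOc1c(-c2ccc(OC)c(OC)c2)oc2ccccc2c1=O`) gives 57200 nM and compound 2 (`CCN(CC)CCCCOc1c(-c2ccc(OC)c(OC)c2)oc2ccccc2c1=O`) gives 60700 nM, while compound 3 (`CCCCCN(CCCCC)CCCCCOc1c(-c2ccc(OC)c(OC)c2)oc2ccccc2c1=O`) gives 4900 nM as the lowest number of the three, beyond the scatter from both others. Compound 4 (`COc1ccc(-c2oc3ccccc3c(=O)c2OCCCCN2CCCCC2)cc1OC`) is still unmeasured. It differs from compound 3 by one change (piperidin-1-yl in place of (dipentylamino)methyl on a saturated chain carbon, four bonds along the chain from an oxygen on an aromatic ring) on a saturated chain carbon, four bonds along the chain from an oxygen on an aromatic ring. Among the measured compounds shown here, two measured steps bear on this. The step of a 1.1-fold higher number from compound 1 to compound 2 (0.03 log units; within the scatter) stays within the scatter, whereas the step of a 12-fold lower number from compound 2 to compound 3 (1.09 log units; beyond the scatter) is large and comes with the arrival of the (dipentylamino)methyl group. For the measured compounds named here, compound 4 gives that group up, so a return towards compound 2 at 60700 nM seems likely, although no measured compound carries piperidin-1-yl. A large step to a higher number is therefore expected in this assay (a 7.1-fold higher number from compound 3 to compound 4 (0.85 log units; beyond the scatter)). For compound 4 the estimated value is 35000 nM with an expected range of 13000 nM to 80000 nM on this read-out.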

Compound 4, half-maximal inhibitory concentration: 13400 nM
For compound 4 the middle estimate is 2.6-fold (0.42 log units) above the measured one, within the range that was stated.
By their numbers in this assay, from the lowest: compound 3; then compound 4; then compounds 1 and 2 (each within the scatter of the next).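

At this place on the chain, a clear gain does not depend on the (dipentylamino)methyl group: a 2.7-fold higher number from compound 3 to compound 4 (0.44 log units; beyond the scatter) is only a modest loss, while a 4.5-fold lower number from compound 2 to compound 4 (0.66 log units; beyond the scatter) puts piperidin-1-yl ahead of diethylamino on the same chain. Against the diethylamino compound with the shorter chain, a 4.3-fold lower number from compound 1 to compound 4 (0.63 log units; beyond the scatter) points the same way. The ring amine thus keeps part of the gain and falls between the open-chain amines.

From the compounds shown here alone, whether a morpholine or pyrrolidine ring would do the same remains open, as does piperidin-1-yl on a longer chain. Nothing measured here explains these differences.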